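This account rests on a few compounds, and the source may have more. Where it says the series, first, only, none or still open, it means among the compounds named here.

Working notes on the series. All three measured compounds share the core of compound 1 `C#CCNC1CCc2c(SCCc3ccc(Br)cc3)cccc21` and differ in the aryl group on the sulfur-bearing chain. In an ADME assay on isolated protein for inhibition of Amine oxidase [flavin-containing] B (Homo sapiens) (on this read-out higher numbers stand for weaker inhibition and lower numbers for stronger inhibition), compound 1 gives 1250 nM. Compound 2 `C#CCNC1CCc2c(SCCc3cccc(C)c3)cccc21` gives 4960 nM, and compound 3 `C#CCNC1CCc2c(SCc3cccc(F)c3)cccc21` gives 11600 nM. Compound 3 therefore holds the highest number of the three measured; compound 2 stands nearest to it and compound 1 furthest away, both gaps beyond the scatter. Among the compounds with values here, the only single-point step on record is a 4.0-fold higher number from compound 1 to compound 2 (0.60 log units; beyond the scatter), in which 3-methylphenyl replaces 4-bromophenyl on a saturated chain carbon, two bonds along the chain from a sulfur.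

Compound 4 `C#CCNC1CCc2c(SCc3ccc(Br)cc3)cccc21` has not been measured. It differs from compound 3 by 4-bromophenyl in place of 3-fluorophenyl on a saturated chain carbon bound to a sulfur. The step from compound 1 to compound 2 bears on this only loosely: it runs the other way, with 4-bromophenyl leaving rather than entering, and it sits on a saturated chain carbon two bonds along the chain from a sulfur rather than on one bound to a sulfur. Taken in reverse, it suggests that 4-bromophenyl entering should lower the number by a modest amount; the expected step is a 3.3-fold lower number from compound 3 to compound 4 (0.52 log units; beyond the scatter). For compound 4 the expected value in this assay is 3500 nM, with a range from 1200 nM to 10000 nM.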

Compound 4, half-maximal inhibitory concentration: 488 nM
Estimate against measurement, compound 4: 7.2-fold (0.86 log units) above, and the stated range ends above it.
By their numbers in this assay, from the lowest: compound 4; then compound 1; then compound 2; then compound 3.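

Within the data shown here, on the saturated chain carbon bound to a sulfur, the aryl group has far more effect in this assay than the earlier compounds could show: 4-bromophenyl in place of 3-fluorophenyl gives a 24-fold lower number from compound 3 to compound 4 (1.38 log units; beyond the scatter) as a large step, although the heavy-atom count, the ring type and the donor and acceptor counts stay the same. Read with a 4.0-fold higher number from compound 1 to compound 2 (0.60 log units; beyond the scatter) as the modest step two bonds along the chain from a sulfur, this makes two pairs in which 4-bromophenyl stands with the lower number, and no compound shown goes against that, though the partner group differs between the pairs. No measurement at hand accounts for the size of the new step or for its difference from the earlier one.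

The compounds shown do not separate the bromine from its placement on the ring, and 3-bromophenyl or 4-fluorophenyl on the same chain carbon would be the pairs to tell the two apart. Also open, as far as these compounds go, is whether the same order holds for 4-chlorophenyl, for unsubstituted phenyl or on a longer chain.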